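A few compounds are considered here, and "the series" means these few. Any claim that something is new, unique, unknown or untested is made for them only; others in the source may bear on it.

In a functional assay on HCT-116 cells (Homo sapiens) for inhibition, read by colorimetric assay, with a stated time of 3 days (on this read-out lower numbers stand for stronger inhibition and higher numbers for weaker inhibition), compound 1 (`O=C(CCCCCCNC(=O)C(O)(O)C(F)(F)F)Nc1ccncc1`) gives 6670 nM and has the lowest number of those available. Compound 3 (`O=C(CCCCCCNC(=O)C(O)(O)C(F)(F)F)Nc1nc(-c2ccccc2)c(-c2ccccc2)s1`) gives 29900 nM as the nearest number, which is higher by more than the usual scatter. Compound 2 (`C/C(=N\O)C(=O)NCCCCCC(=O)Nc1ccccc1`) gives > 100000 nM as a limit of the assay and not a number.

Compound 4 (`O=C(CCCCCCNC(=O)C(O)(O)C(F)(F)F)Nc1ccccc1`) has not yet been measured. It differs from compound 1 in one place, with phenyl in place of pyridin-4-yl on an amide-type nitrogen. The ring keeps its size, and the change is confined to the ring itself.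

Among the measured compounds shown here, no measured pair shows this exact swap, so the expectation rests on very little. Compound 3 carries a much larger group at the same place and gives 29900 nM as a measured number, not a limit. The swap in compound 4 is far smaller than the difference between compound 1 and compound 3, so only a modest shift seems likely. In this assay no step beyond the scatter is expected, and the estimated step is a 1.2-fold higher number from compound 1 to compound 4 (0.08 log units; within the scatter) with no firm direction. For compound 4 the estimated value is 8000 nM with an expected range from 2500 nM to 25000 nM as its limits.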

Compound 4, half-maximal inhibitory concentration: 9140 nM
The estimate for compound 4 lay 1.1-fold (0.06 log units) below the measured number; measured number inside the range.
By their numbers in this assay, from the lowest: compounds 1 and 4 (each within the scatter of the next); then compound 3. At a limit, above all of these: compound 2.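

In this assay, placing phenyl instead of pyridin-4-yl on the amide-type nitrogen gives a 1.4-fold higher number from compound 1 to compound 4 (0.14 log units; within the scatter), so the two compounds cannot be told apart in this test. The earlier compounds shown here could not show this, as none of them offered a comparison at this place between two rings of the same size; this pair shows that the ring nitrogen of pyridin-4-yl, the one hydrogen-bond acceptor in the group that leaves, can give way to carbon without a difference that exceeds the usual variation between repeated measurements. Nothing measured here explains why the two compounds read alike.

Going by these compounds, it remains open whether the phenyl ring of compound 4 tolerates added groups, such as an amine or a carboxylic acid, or whether moving the ring nitrogen to give pyridin-3-yl would leave the number where it stands. A longer chain in place of the one shared by compound 1 and compound 4 is also unexplored here, so the compounds shown say nothing about how chain length affects the number in this assay.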